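Swapping a Piperidine for Cyclohexyl in an Acid Ceramidase Series

A few compounds are considered here, and "the series" means these few. Any claim that something is new, unique, unknown or untested is made for them only; others in the source may bear on it.

Measured compounds:
compound 1, `CC(C)N1CCC(c2ccc3c(c2)oc(=O)n3C(=O)NCCCCc2ccccc2)CC1`, 94 nM
compound 2, `O=C(NCCCCc1ccccc1)n1c2c(oc1=O)CCN(Cc1ccccc1)C2`, 436 nM

Both compounds were tested in an assay on HEK293 cells for inhibition of acid ceramidase (Homo sapiens), read by fluorescence, with stated times of 10 min and 3 h; a lower number here means a stronger inhibitor, a higher number a weaker inhibitor. Compound 1 gives the lower of the two numbers, 94 nM. Compound 2 gives 436 nM, and the gap between the two lies beyond the usual scatter. Among the compounds with values here, the two compounds differ in more than one place at once, so their comparison says nothing about any single change, and no pair differing in one place has been measured.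

The next compound to be measured is compound 3, `O=C(NCCCCc1ccccc1)n1c(=O)oc2cc(C3CCCCC3)ccc21`. It keeps the carbamate, the chain ending in phenyl and the shared core of compound 1, and changes one group: cyclohexyl in place of 1-isopropylpiperidin-4-yl on an aromatic carbon. The ring stays six-membered and non-aromatic, but the nitrogen and its isopropyl branch are gone. Within the data shown here, no measured pair shows this change, so the expectation rests only on compound 1 and on the size of the group exchanged. A modest weakening is expected, not far outside the scatter. Compound 3 is expected to give 160 nM, with a likely range from 45 nM to 600 nM. The step this estimate implies is a 1.7-fold higher number from compound 1 to compound 3 (0.23 log units; within the scatter).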

Compound 3, half-maximal inhibitory concentration: 89 nM
For compound 3 the middle estimate is 1.8-fold (0.25 log units) above the measured one, within the range that was stated.
By their numbers in this assay, from the lowest: compounds 3 and 1 (each within the scatter of the next); then compound 2.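

In this assay, putting cyclohexyl in place of 1-isopropylpiperidin-4-yl on this aromatic carbon gives a 1.1-fold lower number from compound 1 to compound 3 (0.02 log units; within the scatter) and so leaves the two compounds indistinguishable. Within the data shown here, this is the first comparison that differs in one place only, and it shows that at this position neither the ring nitrogen nor the isopropyl branch is required for a number at this level: a ring of carbon only, with 6 heavy atoms rather than 9, serves as well in this assay. Nothing measured here explains why the exchange leaves the number level. Going by these compounds, the result covers only these two six-membered non-aromatic rings, so it remains open whether a flat phenyl ring, a small methyl group, or a group carrying a carboxylic acid at the same aromatic carbon would give a similar number. On these data alone, it is also open whether a piperidin-4-yl ring with a hydrogen on its nitrogen, or one with a larger group such as benzyl there, would match compound 1 and compound 3.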